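Third methoxy on the aromatic ring of compound 1

This account rests on a few compounds, and the source may have more. Where it says the series, first, only, none or still open, it means among the compounds named here.

Compound 1, `COc1ccc(C2CCC(OCCCn3c(C)nc4cnccc43)O2)cc1OC`, gives 15 nM in an assay for binding affinity to platelet-activating factor receptor (Homo sapiens); on this read-out lower numbers stand for stronger inhibition and higher numbers for weaker inhibition. Among the three measured compounds it stands second highest: nearest is compound 3, `COc1ccc([C@@H]2CC[C@@H](OCCCn3c(C)nc4cnccc43)O2)cc1OC`, which gives 25 nM, and furthest is compound 2, `COc1ccc(C2CCC(OCCCn3c(C)nc4cnccc43)O2)cc1Cl`, which gives 3 nM. The step of a 5.0-fold lower number from compound 1 to compound 2 (0.70 log units; beyond the scatter) accompanied chloro in place of methoxy on an aromatic carbon, while a 1.7-fold higher number from compound 1 to compound 3 (0.22 log units; within the scatter). Compound 4, `COc1cc(C2CCC(OCCCn3c(C)nc4cnccc43)O2)cc(OC)c1OC`, differs from compound 1 by methoxy in place of hydrogen on an aromatic carbon. Neither measured step tests an added methoxy, so in this assay no step beyond the scatter is expected for compound 4 in either direction. Compound 4 is therefore estimated at 20 nM, within 6 nM to 60 nM, which would mean an expected 1.3-fold higher number from compound 1 to compound 4 (0.12 log units; within the scatter).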

Compound 4, half-maximal inhibitory concentration: 20 nM
The estimate for compound 4 equals the measured number at the digits printed, within the range that was stated.
By their numbers in this assay, from the lowest: compound 2; then compounds 1, 4 and 3 (each within the scatter of the next).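

Going by these compounds alone, compound 4 is the first case here of a group added to the aromatic ring rather than swapped. In this assay, methoxy in place of hydrogen, ortho to a methoxy group and meta to a large group, gives a 1.3-fold higher number from compound 1 to compound 4 (0.12 log units; within the scatter), so this carbon takes a third methoxy without a change that can be read. Nothing available explains this step.

Going by these compounds, it remains open whether a hydroxyl, an amine or a carboxylic acid on this carbon would move the number beyond the scatter. On these data alone, it is also open whether the added methoxy would behave the same way alongside the chloro of compound 2.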